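The source may report more compounds than this note shows. Statements on the series, on what has been measured and on what is new or still open speak of the compounds shown alone.

Of the compounds shown here, two have so far been tested in a functional assay on A549 cells (Homo sapiens) for inhibition, read by MTT assay, with a stated time of 48 h, tested at 10 uM; a higher number here means more inhibition of growth at the concentration tested, a lower number less inhibition of growth. Compound 1 `COc1ccc(C(=O)/C=C/c2ccc(OCc3cn(Cc4ccccc4)nn3)cc2)cc1` gives 44% in this assay. Compound 2 `O=C(/C=C/c1ccc(OCc2cn(Cc3ccccc3)nn2)cc1)c1ccc([N+](=O)[O-])cc1` was reported in this assay as "not active" (no number reported), so no single number stands for it; the two results show one compound with a measurable effect and one with none reported. Compound 3 `O=C(/C=C/c1ccc(OCc2cn(Cc3ccc(Br)cc3)nn2)cc1)c1ccc([N+](=O)[O-])cc1` has not yet been tested. It differs from compound 2 in one place: bromo in place of hydrogen on an aromatic carbon. Among the compounds with values here, no step between measured compounds carries this change, so there is nothing here to show how large a shift in this assay it brings, or in which direction. With compound 2 reporting "not active" (no number reported), the starting point sits at or near the bottom of the scale, and a single bromo would be expected to move this assay by little if at all, most likely by an amount within the scatter. Compound 3 is therefore expected to give about 15% in this assay, within a range of 0% to 40%, with a fair chance that again only an inactive result is reported.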

Compound 3, percent growth inhibition at one concentration: 18%
Compound 3: the middle estimate sits 3 percentage points below what was measured; the measured number falls inside the stated range.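

No step can be read from this result: in this assay compound 2 has only a report of "not active" and no number, so the change to compound 3 at 18% cannot be sized. Going by these compounds, how far the bromo alone shifts growth inhibition stays open. No evidence here bears on this result.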